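This account rests on a few compounds, and the source may have more. Where it says the series, first, only, none or still open, it means among the compounds named here.

Measured compounds in the series:

compound 1 `Cc1cc(Nc2cc(Cl)cc(Cl)c2)nc(N)n1` gives 27%
compound 2 `Cc1nc(N)nc(Nc2cc(Cl)cc(Cl)c2)c1C` gives 25%

Both numbers come from an assay on cells for inhibition of S-adenosylmethionine decarboxylase proenzyme (Homo sapiens), read by mass spectrometry, at pH 7.2, tested at 180 uM; a higher number here means more inhibition at the concentration tested (going by the name of the read-out), a lower number less inhibition. Among the measured compounds shown here, compound 1 stands highest of the two, but only nominally: the one step measured so far, a number 2 percentage points lower from compound 1 to compound 2 (within the scatter), is within the scatter, so compounds 1 and 2 are not told apart by these data.

The next compound is compound 3 `Cc1cc(Nc2cc(Cl)cc(-c3ccoc3)c2)nc(N)n1`, which differs from compound 1 in one place: furan-3-yl in place of chloro on an aromatic carbon. For the measured compounds named here, no measured step touches this position or this kind of exchange. Going by the values given here, the only step on record, from compound 1 to compound 2, concerns a different place on the shared core and was itself within the scatter, so it carries no information on what a change at the chloro position does. The expectation for compound 3 therefore rests on compound 1 alone, with no evidence for a shift in either direction.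

On that basis the step of a number 1 percentage points higher from compound 1 to compound 3 (within the scatter) is estimated to stay within the scatter. Compound 3 is expected to give about 28% in this assay, with a range from 10% to 50% reflecting the absence of any comparable step.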

Compound 3, a percentage reported as inhibition, at one concentration (the size of the read-out at that concentration, not a potency): 30%
Estimate against measurement, compound 3: 2 percentage points below; low and high end bracket the measured number.
By their numbers in this assay, from the lowest: compounds 2, 1 and 3 (each within the scatter of the next).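

Working notes on the chloro position: in this assay, furan-3-yl in place of chloro on the aromatic carbon gives a number 3 percentage points higher from compound 1 to compound 3 (within the scatter) and so leaves no readable difference, even though a group of 5 heavy atoms with a five-membered aromatic ring and a hydrogen-bond acceptor replaces a single chlorine. Among the compounds shown here, the earlier pair spoke only to methyl in place of hydrogen at a different place on the shared core, so this is the first reading at this position, and it shows that the series keeps its number here with a much larger group in place. No measurement available bears on why the number holds across this exchange.

Still open, as far as these compounds go, is whether a different kind of group on this aromatic carbon, such as a carboxylic acid, a primary amine or a longer alkyl chain, would move the number beyond the scatter. Also open, from the compounds shown here alone, is what an exchange of the remaining chloro group would do, alone or together with furan-3-yl, since compounds 1, 2 and 3 all lie within the scatter of their neighbours at a single tested concentration.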